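The source may report more compounds than this note shows. Statements on the series, on what has been measured and on what is new or still open speak of the compounds shown alone.

Compound 1 `Nc1ccc2cccc(OCCC(F)(F)F)c2n1` carries a 3,3,3-trifluoropropyl group on an oxygen on an aromatic ring. In an assay on cells with melanin-concentrating hormone receptor 1 (Homo sapiens) as the target, read by radioligand binding (a lower number here means a stronger inhibitor, a higher number a weaker inhibitor), compound 1 gives 722 nM, the higher of the two numbers shown. Compound 2 `CC(C)Oc1cccc2ccc(N)nc12` gives 437 nM, and the step reads a 1.7-fold lower number from compound 1 to compound 2 (0.22 log units; within the scatter). Compound 3 `Nc1ccc2cccc(OC3CCCC3)c2n1` is reported only as a limit of the assay, > 2000 nM. The cyclopentyl group thus gives an at least 2.7-fold higher number from compound 1 to compound 3 (0.44 log units; beyond the scatter) and an at least 4.5-fold higher number from compound 2 to compound 3 (0.66 log units; beyond the scatter). Compound 4 `COC(C)(C)CCOc1cccc2ccc(N)nc12` differs from compound 1 by 1-methoxy-1-methylethyl in place of trifluoromethyl on a saturated chain carbon, two bonds along the chain from an oxygen on an aromatic ring. The entering group is bulkier than the trifluoromethyl it replaces, so the step to compound 3 bears on it more than the step to compound 2, and a modest weakening is expected. Compound 4 is estimated at 1300 nM, with a range from 500 nM to 3500 nM, which means a 1.8-fold higher number from compound 1 to compound 4 (0.26 log units; within the scatter).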

Compound 4, half-maximal inhibitory concentration: 132 nM
Compound 4: middle estimate off by 9.8-fold (0.99 log units), on the high side; measured number outside the range, below it.
By their numbers in this assay, from the lowest: compound 4; then compounds 2 and 1 (each within the scatter of the next). At a limit, above all of these: compound 3.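

At this place on the chain, 1-methoxy-1-methylethyl in place of trifluoromethyl gives a 5.5-fold lower number from compound 1 to compound 4 (0.74 log units; beyond the scatter) in this assay. The earlier steps shown here changed the group on the oxygen as a whole, whereas this one shows that changing only the end of the chain can also move the number, here downward, with a group that has more heavy atoms and a hydrogen-bond acceptor. Nothing measured here gives a reason for this step.

On these data alone, it remains open whether the methoxy oxygen or the branched carbon accounts for the step. A tert-butyl or a hydroxy group at this place would help separate the two.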